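Series notes: trifluoromethyl for methyl, compound 4 expected

The source may report more compounds than this note shows. Statements on the series, on what has been measured and on what is new or still open speak of the compounds shown alone.

Measured so far:
compound 1 `Cc1ccc(CO/N=C2/C(c3c[nH]c4ccc(Br)cc34)=Nc3ccc(Br)cc32)cc1` — 10600 nM
compound 2 `Fc1ccc(CO/N=C2/C(c3c[nH]c4ccccc34)=Nc3ccccc32)cc1` — 20700 nM
compound 3 `FC(F)(F)c1ccc(CO/N=C2/C(c3c[nH]c4ccccc34)=Nc3ccccc32)cc1` — 24100 nM

All three numbers come from a functional assay on NCI-H460 cells (Homo sapiens) for cytotoxicity, read by MTT assay, with a stated time of 2 days; on this read-out higher numbers stand for weaker inhibition and lower numbers for stronger inhibition. Compound 1 sits at the lower end of the three numbers; its gap to compound 2 is within the usual scatter, whereas its gap to compound 3 lies beyond it.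

The next compound, compound 4 `FC(F)(F)c1ccc(CO/N=C2/C(c3c[nH]c4ccc(Br)cc34)=Nc3ccc(Br)cc32)cc1`, differs from compound 1 in one place: trifluoromethyl in place of methyl on an aromatic carbon. Among the compounds with values here, no measured pair shows exactly this exchange. The nearest case is the step of a 1.2-fold higher number from compound 2 to compound 3 (0.07 log units; within the scatter), which also ends in a trifluoromethyl at the same position of the benzyl arm, though it starts from fluoro rather than methyl and is carried out on the core without bromine. That step stayed within the scatter.

On that basis the expectation for compound 4 in this assay is a step from compound 1 of no meaningful size, a 1.2-fold higher number from compound 1 to compound 4 (0.07 log units; within the scatter), with a slight lean to a higher number. Compound 4 is therefore estimated at 12500 nM, with a range of 6000 nM to 26000 nM.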

Compound 4, half-maximal inhibitory concentration: 11200 nM
For compound 4 the middle estimate is 1.1-fold (0.05 log units) above the measured one, within the range that was stated.
By their numbers in this assay, from the lowest: compounds 1, 4, 2 and 3 (each within the scatter of the next, the first and the last beyond it).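

In this assay, the direct exchange of methyl for trifluoromethyl on this aromatic carbon, para to a large group, gives a 1.1-fold higher number from compound 1 to compound 4 (0.02 log units; within the scatter). Within the data shown here, this is the first reading of the exchange from methyl, and it comes on the bromine-bearing core, whereas the earlier trifluoromethyl step, a 1.2-fold higher number from compound 2 to compound 3 (0.07 log units; within the scatter), started from fluoro on the core without bromine. Both listed steps at this position therefore stay within the scatter, with no pair shown going against this, so across these two pairs the read-out barely registers the change from methyl or fluoro to trifluoromethyl, and no information is available to explain this flat behaviour.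

What the compounds shown leave open is whether the position stays this insensitive to a group of another kind, such as an amine, a carboxylic acid or a longer alkyl chain in place of the trifluoromethyl. Compound 3 and compound 4 differ in both bromines at once, so the share of each bromine cannot be read from them.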